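Removing One Trifluoromethyl Group From Compound 2

A few compounds are considered here, and "the series" means these few. Any claim that something is new, unique, unknown or untested is made for them only; others in the source may bear on it.

Of the compounds shown here, two have been measured in a functional assay on HCT-15 cells (Homo sapiens) for inhibition, read by sulforhodamine B assay, with a stated time of 48 h, tested at 100 uM; a lower number here means a stronger effect, a higher number a weaker effect of the compound at the concentration tested. Compound 1 `O=C(Nc1cccc(-n2cc(-c3ccncc3)c(-c3cc(O)cc(Cl)c3)n2)c1)Nc1ccc(Cl)c(Cl)c1` gives -23% in this assay . Compound 2 `COc1cc(Cl)cc(-c2nn(-c3cccc(NC(=O)Nc4cc(C(F)(F)F)cc(C(F)(F)F)c4)c3)cc2-c2ccncc2)c1` gives -83% in this assay , the lowest of the two numbers, and the gap to compound 1 lies beyond the usual scatter of this kind of measurement.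

Compound 3 `COc1cc(Cl)cc(-c2nn(-c3cccc(NC(=O)Nc4cccc(C(F)(F)F)c4)c3)cc2-c2ccncc2)c1` has not yet been measured. It differs from compound 2 in one place: hydrogen in place of trifluoromethyl on an aromatic carbon. Among the measured compounds shown here, no pair of measured compounds differing in only this way is available, so the effect of this change has to be guessed rather than read from a step.

Compound 2 is expected to serve as the anchor, and because compound 2 gives -83%, compound 3 is expected to stay in the same strongly negative region. The step from compound 2 to compound 3 is estimated as small, most likely a modest weakening that may fall within the scatter, a number 13 percentage points higher from compound 2 to compound 3 (beyond the scatter). Compound 3 is therefore estimated at -70%, with a range from -95% to -40%.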

Compound 3, a percentage reported as activity, at one concentration (the size of the read-out at that concentration, not a potency): -72%
Compound 3: middle estimate off by 2 percentage points, on the high side; the range from low to high includes it.
By their numbers in this assay, from the lowest: compound 2; then compound 3; then compound 1.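

In this assay, replacing one trifluoromethyl group with hydrogen on this six-membered aromatic ring of carbon only gives a number 11 percentage points higher from compound 2 to compound 3 (beyond the scatter), a modest step that still lies beyond the usual scatter. This position is therefore not indifferent to the change, yet it does not depend on this group alone for a strongly negative read-out: compound 3, which keeps its other trifluoromethyl group, gives -72%. No measurement shown here accounts for the size of this step.

The compounds shown leave open what happens when the remaining trifluoromethyl group is also replaced by hydrogen, and whether the same change would give a step of similar size in a compound with a different substitution pattern on the rest of the molecule, such as compound 1. They also leave open whether a nitrile or an amine in this place would give a read-out closer to that of compound 2 or to that of compound 3, or one outside that span altogether.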